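The source may report more compounds than this note shows. Statements on the series, on what has been measured and on what is new or still open speak of the compounds shown alone.

Among the measured compounds shown here, in a functional assay on HCT-116 cells (Homo sapiens) for inhibition, read by MTT assay, with a stated time of 48 h (on this read-out higher numbers stand for weaker inhibition and lower numbers for stronger inhibition), compound 3 (`COc1cc(-c2nnc(SCC(=O)c3ccc(F)cc3)n2-c2ccc(N(C)C)cc2)cc(OC)c1OC`) gives 31100 nM, the only true number among the compounds measured so far. Compound 1 (`COc1ccc(NC(=O)CSc2nnc(-c3cc(OC)c(OC)c(OC)c3)n2-c2ccc(OC)cc2)cc1`) reads > 60000 nM, which is a limit. Compound 2 (`COc1cc(-c2nnc(SCc3ccc(F)cc3)n2-c2ccc(N(C)C)cc2)cc(OC)c1OC`) reads > 60000 nM, which is also a limit.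

Compound 4 (`COc1ccc(NC(=O)CSc2nnc(-c3cc(OC)c(OC)c(OC)c3)n2-c2ccc(N(C)C)cc2)cc1`) departs from compound 3 by one change: (4-methoxyphenyl)amino in place of 4-fluorophenyl on a carbonyl carbon. In words, (4-methoxyphenyl)amino replaces 4-fluorophenyl on a carbonyl carbon, turning (4-fluorophenyl)carbonyl into (4-methoxyphenyl)carbamoyl.

For the measured compounds named here, no measured step covers this exact swap. The nearest is an at least 1.9-fold lower number from compound 2 to compound 3 (0.28 log units; that floor lies within the scatter), which brought in the (4-fluorophenyl)carbonyl group and offers only weak guidance. Compound 1 also carries (4-methoxyphenyl)carbamoyl, and its value of > 60000 nM is a limit, so the expectation leans cautiously towards weaker inhibition.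

The expected change in this assay, a 1.3-fold higher number from compound 3 to compound 4 (0.11 log units; within the scatter), stays within the usual scatter, although a result reported only as a limit is quite possible. The estimate for compound 4 is 40000 nM, with an expected range from 15000 nM to 60000 nM.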

Compound 4, half-maximal inhibitory concentration: > 60000 nM
Compound 4 ended at the assay's limit; the forecaster's own chance of this, stated with the estimate: 45%; middle value at least 1.5-fold (0.17 log units) away from the limit.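

In this assay, putting (4-methoxyphenyl)amino in place of 4-fluorophenyl on the carbonyl carbon gives an at least 1.9-fold higher number from compound 3 to compound 4 (0.28 log units; that floor lies within the scatter), so the step shown by these values does not clear the usual scatter. Compound 3, with its (4-fluorophenyl)carbonyl group, is now the only one of the compounds shown that gives a true number, and the (4-methoxyphenyl)carbamoyl group has not given one with either dimethylamino or methoxy on the other aromatic ring, while the steps from compound 1 and compound 2 to compound 4 cannot be read. The size of the change from compound 3 therefore stays unresolved, and the series offers little to compare: the limit of > 60000 nM in this assay, at which 3 of the 4 values shown sit.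

As far as these compounds go, how far compound 4 really lies from compound 3 stays open. Also open, from the compounds shown here alone, is whether a smaller group on that carbonyl carbon, such as a plain amine or the hydroxyl of a carboxylic acid, would give a true number and a step beyond the scatter.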